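A few compounds are considered here, and "the series" means these few. Any claim that something is new, unique, unknown or untested is made for them only; others in the source may bear on it.

Measured compounds:
Compound 1 `Oc1ccccc1-c1cc(-c2cccs2)cc(-c2ccccc2O)n1` gives > 50000 nM in a functional assay on DU-145 cells (Homo sapiens) for cytotoxicity, read by CCK-8 assay (a lower number here means a stronger inhibitor, a higher number a weaker inhibitor), which is only a limit of the assay.
Compound 2 `Oc1ccccc1-c1cc(-c2ccsc2)cc(-c2ccccc2O)n1` gives > 50000 nM in this assay, again only a limit.

Compound 2 therefore stands at the limit, as does compound 1 (the limit of > 50000 nM in this assay, at which 2 of the 2 values shown sit), and the step that the two limits leave unreadable from compound 1 to compound 2 is unreadable. Compound 3 `Oc1ccccc1-c1cc(-c2ccco2)cc(-c2ccccc2O)n1` differs from compound 2 by furan-2-yl in place of thiophen-3-yl on an aromatic carbon. For the measured compounds named here, the only measured step gives no readable size or direction, and neither compound has yet given a number. The step is expected to be a step that the limit leaves unreadable from compound 2 to compound 3. Compound 3 is expected at 80000 nM, range 30000 nM to 300000 nM, most likely again reported as a limit.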

Compound 3, half-maximal inhibitory concentration: > 50000 nM
Compound 3: no number, only a limit; the forecaster's own chance of this, stated with the estimate: 85%; the middle value lies beyond the limit too.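

No step among compound 1, compound 2 and compound 3 can be read: the limit of > 50000 nM in this assay, at which 3 of the 3 values shown sit.

The compounds shown leave open how thiophen-2-yl, thiophen-3-yl and furan-2-yl compare, and whether any group at this place gives a number in this assay.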